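The compounds below may be only part of what the source reports. "The series", "measured", "known", "first", "only" and "open" are said of these compounds alone.

Measured so far: compound 1 `OC(CCCN1CCN(c2ncc(F)cn2)CC1)C1CCCCC1` and compound 2 `Fc1ccc(CCCCN2CCN(c3ncc(F)cn3)CC2)cc1`. In an assay (Cavia porcellus) for displacement of a labelled ligand from Sigma non-opioid intracellular receptor 1 (Homo sapiens) (a lower number here means a stronger inhibitor, a higher number a weaker inhibitor), compound 1 gives 12 nM, and in this assay compound 2 gives 23 nM. Compound 2 stands at the higher of these two numbers, but the step of a 1.9-fold higher number from compound 1 to compound 2 (0.28 log units; within the scatter) lies within the scatter, so the two are not distinguished.

Compound 3 `Fc1ccc(OCCCN2CCN(c3ncc(F)cn3)CC2)cc1` differs from compound 2 by 4-fluorophenoxy in place of 4-fluorobenzyl on a saturated chain carbon, three bonds along the chain from an amine nitrogen in a ring. Among the measured compounds shown here, the only measured step at this place, a 1.9-fold higher number from compound 1 to compound 2 (0.28 log units; within the scatter), is a larger structural swap that left the number essentially unchanged, so no shift beyond the scatter is expected. Compound 3 is expected to give 25 nM in this assay, within 8 nM to 80 nM, a step of a 1.1-fold higher number from compound 2 to compound 3 (0.04 log units; within the scatter).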

Compound 3, half-maximal inhibitory concentration: 89 nM
Estimate against measurement, compound 3: 3.6-fold (0.55 log units) below, and the stated range ends below it.
By their numbers in this assay, from the lowest: compounds 1 and 2 (each within the scatter of the next); then compound 3.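

In this assay this position now shows a change beyond the scatter: 4-fluorophenoxy in place of 4-fluorobenzyl, with the same count of heavy atoms and the same aromatic ring, gives a 3.9-fold higher number from compound 2 to compound 3 (0.59 log units; beyond the scatter) here. Cyclohexyl(hydroxy)methyl replaced by 4-fluorophenoxy gives a 7.4-fold higher number from compound 1 to compound 3 (0.87 log units; beyond the scatter) at this place, so the position does respond to what the chain carries. No evidence is available that bears on this shift. The compounds shown leave open whether a sulfur atom or an amine nitrogen in place of the oxygen would give the same number. They also leave open how a longer chain would read.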